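The compounds below may be only part of what the source reports. "The series", "measured", "known", "first", "only" and "open" are said of these compounds alone.

Values in a functional assay on BGC-823 cells (Homo sapiens) for cytotoxicity, read by MTT assay, with a stated time of 48 h (a lower number here means a stronger inhibitor, a higher number a weaker inhibitor), for the three measured compounds:

Compound 1, `O=C(CSc1nnc(-c2ccncc2)o1)N/N=C/c1ccccc1`: 22100 nM
Compound 2, `O=C(CSc1nnc(-c2ccncc2)o1)N/N=C/c1ccc(Br)cc1`: 24500 nM
Compound 3, `O=C(CSc1nnc(-c2ccncc2)o1)N/N=C/c1cccc(F)c1`: 27500 nM

All three compounds share one core and differ only in the ring attached to the carbon with a double bond to nitrogen. Compound 3 gives the highest of the three numbers, but the steps of a 1.2-fold higher number from compound 1 to compound 3 (0.09 log units; within the scatter) and a 1.1-fold higher number from compound 2 to compound 3 (0.05 log units; within the scatter) both lie within the scatter, so on these data the three compounds cannot be told apart.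

Compound 4 is `O=C(CSc1nnc(-c2ccncc2)o1)N/N=C/c1ccccc1O`. It differs from compound 3 in one place: 2-hydroxyphenyl in place of 3-fluorophenyl on a carbon with a double bond to nitrogen. Every measured step changes the same ring: a 1.1-fold higher number from compound 1 to compound 2 (0.04 log units; within the scatter), a 1.2-fold higher number from compound 1 to compound 3 (0.09 log units; within the scatter) and a 1.1-fold higher number from compound 2 to compound 3 (0.05 log units; within the scatter). None of them moves the number beyond the scatter. For the measured compounds named here, the change to compound 4 is of the same kind, one group on that ring swapped for another, although the incoming ring carries one hydrogen-bond donor and one hydrogen-bond acceptor, which none of the measured rings has. On the measured steps, no step beyond the scatter is expected: a 1.1-fold lower number from compound 3 to compound 4 (0.04 log units; within the scatter). Going by the values given here, compound 4 is therefore estimated at 25000 nM, within a range from 11000 nM to 55000 nM, kept wide because no measured compound carries a donor on this ring.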

Compound 4, half-maximal inhibitory concentration: 6160 nM
Compound 4: the middle estimate sits 4.1-fold (0.61 log units) above what was measured; measured number below the stated range.
By their numbers in this assay, from the lowest: compound 4; then compounds 1, 2 and 3 (each within the scatter of the next).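

In this assay, for the compounds shown here, the ring on the carbon with a double bond to nitrogen proves able to move the number: a 4.5-fold lower number from compound 3 to compound 4 (0.65 log units; beyond the scatter) and a 4.0-fold lower number from compound 2 to compound 4 (0.60 log units; beyond the scatter) and a 3.6-fold lower number from compound 1 to compound 4 (0.55 log units; beyond the scatter) are the first steps in this set to pass beyond the scatter, though all three remain modest. The last of these is the simplest to read, as its only change is the addition of a hydroxy group to the ring, whereas bromo and fluoro in place of hydrogen left the number within the scatter, so among the groups shown, hydroxy alone shifts it. The 2-hydroxyphenyl ring is also the only ring here with a hydrogen-bond donor and a hydrogen-bond acceptor, but that is a count and not an explanation, and no measurement shown accounts for the lower number.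

The compounds shown leave open whether a methoxy group or an amine on this ring would give a similar step, which would help show whether the hydroxy group itself matters. They also leave open whether the hydroxy group would have the same effect at another place on the ring.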